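This account rests on a few compounds, and the source may have more. Where it says the series, first, only, none or still open, it means among the compounds named here.

Measured so far in a functional assay on MCF7 cells (Homo sapiens) for antiproliferative activity, read by MTT assay, with a stated time of 48 h; a higher number here means a weaker inhibitor, a lower number a stronger inhibitor:
compound 1 `Cc1ccc(-c2nnc(NC(=O)/C=C/c3ccccc3)s2)cc1`: 1.19 ug/mL
compound 2 `O=C(/C=C/c1ccc(F)cc1)Nc1nnc(-c2ccc(Cl)cc2)s1`: 1.58 ug/mL

Compound 2 gives 1.58 ug/mL and compound 1 gives 1.19 ug/mL. These two values lie within the scatter of each other, so no order can be read between them. Going by the values given here, the two compounds also differ in more than one place, so the series offers no measured single-change step yet.

Compound 3 `O=C(/C=C/c1ccccc1)Nc1nnc(-c2ccc(Cl)cc2)s1` is the next to be read. It has hydrogen in place of fluoro on an aromatic carbon, para to a large group, and the 4-fluorophenyl of compound 2 thus becomes phenyl: hydrogen in place of fluoro on an aromatic carbon. Among the compounds with values here, compound 1 also carries phenyl there and gives 1.19 ug/mL, which offers the only indirect guide. Within the data shown here, no measured step shows what this change does, so no shift beyond the scatter is expected in this assay, in either direction. The estimated 1.1-fold lower number from compound 2 to compound 3 (0.05 log units; within the scatter) is therefore small. For compound 3 the expected value is 1.4 ug/mL, with an estimated range of 0.7 ug/mL to 2.8 ug/mL.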

Compound 3, half-maximal inhibitory concentration: 1.42 ug/mL
Estimate against measurement, compound 3: 1.0-fold (0.01 log units) below; the range from low to high includes it.
By their numbers in this assay, from the lowest: compounds 1, 3 and 2 (each within the scatter of the next).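

Going by these compounds alone, the first measured single-change step at this position, 4-fluorophenyl to phenyl in this assay, is a 1.1-fold lower number from compound 2 to compound 3 (0.05 log units; within the scatter) and so shows no readable effect of hydrogen in place of fluoro on this aromatic carbon, para to a large group. The second step, chloro in place of methyl on an aromatic carbon, is a 1.2-fold higher number from compound 1 to compound 3 (0.08 log units; within the scatter) and likewise shows no readable effect, so neither single change separates the three compounds in this assay. No independent data bear on these results.

The compounds shown carry only hydrogen and fluoro at the first of these places and only methyl and chloro at the second, so it remains open whether a group of another kind there, such as an amine, a methoxy group or a carboxylic acid, would move the number beyond the scatter. On these data alone, the amide and the chain leading to the unsubstituted or fluorinated phenyl are the same throughout, and how the series responds to a change there, for instance a longer chain, also remains open.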